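Swapping the aryl group on the hydrazone carbon

A few compounds are considered here, and "the series" means these few. Any claim that something is new, unique, unknown or untested is made for them only; others in the source may bear on it.

Measured compounds:
compound 1 `O=C(N/N=C/c1ccc(F)cc1)c1cccnc1Nc1cccc(C(F)(F)F)c1`: 36.5%
compound 2 `COc1cccc(/C=N/NC(=O)c2cccnc2Nc2cccc(C(F)(F)F)c2)c1`: 14.9%

In a functional assay on the whole organism (strain Wistar) for inhibition, with Rattus norvegicus as the target, read by paw edema, with a stated time of 4 h, at a dose of 10 mg/kg by the intraperitoneal route (on this read-out higher numbers stand for more inhibition at the one dose given (going by the name of the read-out) and lower numbers for less inhibition), compound 1 gives 36.5%, the highest of the two numbers. Compound 2 gives 14.9%, and the step of a number 21.6 percentage points lower from compound 1 to compound 2 (beyond the scatter) shows that replacing the aryl group on the carbon with a double bond to nitrogen can cost a good part of the inhibition.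

Compound 3 `O=C(N/N=C/c1ccncc1)c1cccnc1Nc1cccc(C(F)(F)F)c1` differs from compound 1 by pyridin-4-yl in place of 4-fluorophenyl on a carbon with a double bond to nitrogen. Within the data shown here, the only measured step touching this position is a number 21.6 percentage points lower from compound 1 to compound 2 (beyond the scatter), a modest drop for a different aryl swap. Pyridin-4-yl is not the same change as 3-methoxyphenyl, so the size carries over only loosely, but a move downward of similar or smaller size is the expectation. Compound 3 is therefore estimated at 27%, between 12% and 42%, which means an expected step of a number 9.5 percentage points lower from compound 1 to compound 3 (within the scatter).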

Compound 3, a percentage reported as inhibition, in the whole organism at one dose (the size of the read-out at that dose, not a potency): 45.9%
Beside the measured number, compound 3's estimate is 18.9 percentage points below it; the measured number lies above the stated range.
By their numbers in this assay, from the lowest: compound 2; then compounds 1 and 3 (each within the scatter of the next).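

In this assay, pyridin-4-yl on the carbon with a double bond to nitrogen gives a number 9.4 percentage points higher from compound 1 to compound 3 (within the scatter), so a ring with a hetero atom can take the place of 4-fluorophenyl with no change beyond the scatter. The other new step, a number 31 percentage points higher from compound 2 to compound 3 (beyond the scatter), is large, and it shows that the drop seen with 3-methoxyphenyl is not a general cost of replacing 4-fluorophenyl at this position. No measurement at hand accounts for these differences.

The compounds shown leave open whether the low number of compound 2 goes with the methoxy group itself or with where it sits on the ring. They also leave open how a piperidine ring, or a phenyl ring carrying a carboxylic acid, would read on this carbon.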